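The source may report more compounds than this note shows. Statements on the series, on what has been measured and on what is new or still open speak of the compounds shown alone.

Measured compounds:
- compound 1, `Cc1ccc([C@@H]2CN(C)[C@]3(C(=O)Nc4ccccc43)[C@]23Cc2ccccc2C3=O)cc1`: 23.8%
- compound 2, `CN1C[C@@H](c2cccs2)[C@@]2(Cc3ccccc3C2=O)[C@@]12C(=O)Nc1ccccc12`: 39.1%
- compound 3, `Cc1ccc([C@@H]2CN(C)[C@]3(C(=O)N(C)c4ccccc43)[C@]23Cc2ccccc2C3=O)cc1`: 8%

In a functional assay on the whole organism (strain Wister albino) for inhibition, with Rattus norvegicus as the target, read by paw edema, with stated times of 1 h and 2 h, at a dose of 50 mg/kg by the intraperitoneal route (on this read-out higher numbers stand for more inhibition at the one dose given (going by the name of the read-out) and lower numbers for less inhibition), compound 3 gives the lowest of the three numbers. The change from compound 1 to compound 2 is thiophen-2-yl in place of 4-methylphenyl on a saturated ring carbon and made the step of a number 15.3 percentage points higher from compound 1 to compound 2 (beyond the scatter). The cores of compound 1 and compound 3 differ by methyl in place of hydrogen on an amide-type nitrogen in a ring, a change that made the step of a number 15.8 percentage points lower from compound 1 to compound 3 (beyond the scatter).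

Compound 4, `CN1C(=O)[C@@]2(c3ccccc31)N(C)C[C@@H](c1cccs1)[C@@]21Cc2ccccc2C1=O`, is not yet measured in this assay. It arises from compound 3 by thiophen-2-yl in place of 4-methylphenyl on a saturated ring carbon, the same change as from compound 1 to compound 2. If that step carries over to the methylated core, compound 4 is expected to show roughly a number 15 percentage points higher from compound 3 to compound 4 (beyond the scatter) in this assay, resting on the single earlier step of a number 15.3 percentage points higher from compound 1 to compound 2 (beyond the scatter). The estimate for compound 4 is therefore 23%, expected between 10% and 38%.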

Compound 4, a percentage reported as inhibition, in the whole organism at one dose (the size of the read-out at that dose, not a potency): 10.8%
Compound 4: middle estimate off by 12.2 percentage points, on the high side, within the range that was stated.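

In this assay thiophen-2-yl in place of 4-methylphenyl gives a number 2.8 percentage points higher from compound 3 to compound 4 (within the scatter) on the core carrying the methyl on the amide-type nitrogen, and the two steps for this change do not differ beyond the scatter: the same change on two cores in this assay, a number 15.3 percentage points higher (beyond the scatter) from compound 1 to compound 2 and a number 2.8 percentage points higher (within the scatter) from compound 3 to compound 4, 12.5 percentage points apart, within the scatter of two such steps.
Methyl in place of hydrogen on that nitrogen gives a number 28.3 percentage points lower from compound 2 to compound 4 (beyond the scatter) and lowers the number on both cores: the same change on two cores in this assay, a number 15.8 percentage points lower (beyond the scatter) from compound 1 to compound 3 and a number 28.3 percentage points lower (beyond the scatter) from compound 2 to compound 4, 12.5 percentage points apart, within the scatter of two such steps.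
Both changes are thus compatible with carrying over between these two cores, but two pairs fix the size of neither step, and the gain from thiophen-2-yl is not confirmed on the methylated core.

Still open, going by these compounds, is whether a longer chain on the amide-type nitrogen behaves as methyl does. Also open, on these data alone, is how an aryl group bearing an amine or a carboxylic acid compares with thiophen-2-yl on the saturated ring carbon.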